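The compounds below may be only part of what the source reports. "The series", "measured", "known", "first", "only" and "open" are said of these compounds alone.

Compound 1 `COc1ccc(-c2nc3cc(F)ccc3s2)cc1` is the weaker of the two measured compounds in a functional assay on HCC 2998 cells (Homo sapiens) for antiproliferative activity; a higher number here means a weaker inhibitor of growth, a lower number a stronger inhibitor of growth: compound 1 gives 12400 nM. Going by the values given here, compound 2 `COc1cc(-c2nc3cc(F)ccc3s2)ccc1O` is the only other measured compound, and in this assay compound 2 gives 1040 nM, a gap beyond the scatter. Compound 3 `COc1ccc(-c2nc3cc(F)ccc3s2)cc1OC` is not yet measured; it differs from compound 1 by methoxy in place of hydrogen on an aromatic carbon, the new group sitting ortho to a methoxy group. Among the compounds with values here, no measured pair shows this change, so any expectation rests on compounds 1 and 2 alone. The step from compound 1 to compound 3 is expected to lower the number, a 2.5-fold lower number from compound 1 to compound 3 (0.39 log units; beyond the scatter), because compound 2 gives 1040 nM. Compound 3 is estimated at 5000 nM, within 1500 nM to 16000 nM.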

Compound 3, concentration for 50% growth inhibition: 0.25 nM
The estimate for compound 3 lay 20000-fold (4.30 log units) above the measured number; measured number below the stated range.
By their numbers in this assay, from the lowest: compound 3; then compound 2; then compound 1.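

In this assay, methoxy in place of hydrogen on an aromatic carbon, ortho to a methoxy group, gives a 50000-fold lower number from compound 1 to compound 3 (4.70 log units; beyond the scatter), a large step that neither earlier compound hinted at. Methyl in place of hydrogen on an oxygen on the aromatic ring gives a 4200-fold lower number from compound 2 to compound 3 (3.62 log units; beyond the scatter), so both steps ending at compound 3 are large, and the full pair of methoxy groups outdoes compound 2 with its single methoxy group. Nothing measured here accounts for the size of these steps. Open, on these data alone, is whether an ethoxy group or an amine in place of the new methoxy would keep so low a number.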